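A few compounds are considered here, and "the series" means these few. Any claim that something is new, unique, unknown or untested is made for them only; others in the source may bear on it.

Of the compounds shown here, three sharing one core have been tested in an assay for inhibition of Indoleamine 2,3-dioxygenase 1 (Homo sapiens), read by spectrophotometry, with stated times of 1 h and 4 h; on this read-out higher numbers stand for weaker inhibition and lower numbers for stronger inhibition. Compound 1 `CC(=O)Nc1ccc(S(=O)(=O)NNc2ccc(C)cc2)cc1` gives 51 nM, compound 2 `CC(=O)Nc1ccc(S(=O)(=O)NNc2ccc(Br)cc2)cc1` gives 130 nM, and compound 3 `CC(=O)Nc1ccc(S(=O)(=O)NNc2ccc(Br)c(F)c2)cc1` gives 205 nM. Compound 3 therefore shows the highest number of the three; its gap to compound 2 lies within the scatter, while its gap to compound 1 lies beyond it. The two steps between measured compounds are a 2.5-fold higher number from compound 1 to compound 2 (0.41 log units; beyond the scatter), a modest change, and a 1.6-fold higher number from compound 2 to compound 3 (0.20 log units; within the scatter), which stays within the scatter.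

Compound 4 `CC(=O)Nc1ccc(S(=O)(=O)NNc2ccc(Br)c(C)c2)cc1` has not yet been measured. It differs from compound 3 in one place: methyl in place of fluoro on an aromatic carbon. Both measured steps bear on this change. The first shows a modest rise in the number when bromo replaced methyl; the second shows a smaller rise, within the scatter, when fluoro entered. Taken together, they point to a small effect for exchanging fluoro for methyl. The step in this assay from compound 3 to compound 4 is therefore expected to be a 1.2-fold lower number from compound 3 to compound 4 (0.08 log units; within the scatter), nothing beyond the scatter. Compound 4 is thus estimated at 170 nM, with a range from 70 nM to 400 nM.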

Compound 4, half-maximal inhibitory concentration: 58 nM
Compound 4: middle estimate off by 2.9-fold (0.47 log units), on the high side; the whole stated range lies above it.
By their numbers in this assay, from the lowest: compounds 1 and 4 (each within the scatter of the next); then compounds 2 and 3 (each within the scatter of the next).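

In this assay, this position, ortho to a bromo group, proves sensitive to what sits on it: methyl in place of fluoro gives a 3.5-fold lower number from compound 3 to compound 4 (0.55 log units; beyond the scatter), and methyl in place of hydrogen gives a 2.2-fold lower number from compound 2 to compound 4 (0.35 log units; beyond the scatter). Among these compounds, the earlier swap of hydrogen for fluoro on this carbon stayed within the scatter, so these are the first changes here that clearly move the number, and both point towards stronger inhibition. Fluoro and methyl each count as one heavy atom with no hydrogen-bond donors or acceptors, and no measurement at hand accounts for the gap between them.

The compounds shown leave open whether the gain stops at methyl or continues with a longer chain such as ethyl, and how a methoxy group or an amine would behave on the same carbon. On these data alone, it also remains open whether methyl on this carbon would give a similar step if the bromo group were replaced by another group, such as chloro, as every compound with a group on this carbon also carries bromo.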